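The source may hold more compounds than are shown below. What is called first, only, known or untested is meant among the compounds shown, and "the series" means these compounds.

Compound 1 `O=C(Nc1ccc2sc(-c3cccc(F)c3)nc2c1)N1CCCCC1` | > 50 uM
Compound 2 `O=C(Nc1ccc2sc(-c3ccc(F)c(F)c3)nc2c1)N1CCCCC1` | > 50 uM

In an ADME assay on HepG2 cells (Homo sapiens) for inhibition, read by resazurin assay, with a stated time of 48 h (a lower number here means that less compound is needed, a higher number that more compound is needed for the effect), compound 2 stands at > 50 uM which is a limit of the assay and not a number. Compound 1 gives > 50 uM and that too is a limit. The measurements so far therefore amount to the limit of > 50 uM in this assay, at which 2 of the 2 values shown sit, and nothing firmer. Compound 3 `O=C(Nc1ccc2sc(-c3ccccc3F)nc2c1)N1CCCCC1` carries 2-fluorophenyl in place of 3,4-difluorophenyl on an aromatic carbon. For the measured compounds named here, the only measured step that bears on this change is fluoro in place of hydrogen on an aromatic carbon (a step that the two limits leave unreadable from compound 1 to compound 2) and it has no readable size. With no size to carry over, no step beyond the usual scatter is expected in this assay in either direction, and another limit is the likeliest reading. The expected step is thus (a step that the limit leaves unreadable from compound 2 to compound 3). Compound 3 is estimated at (60 uM), with an expected range of (30 uM to 120 uM).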

Compound 3, concentration for 90% of the maximal effect: > 50 uM
Compound 3: a limit, no number; the forecaster's own chance of this, stated with the estimate: 85%; the middle value lies beyond the limit too.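

In this assay compound 3 gives > 50 uM, which is a limit of the assay and not a number. The steps linking compound 1, compound 2 and compound 3 therefore cannot be read. Going by these compounds, what concentration each compound needs for the effect, and whether 3-fluorophenyl, 3,4-difluorophenyl and 2-fluorophenyl differ in this, stays open.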